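Swapping the aryl on the carbonyl: from aminophenyl to dimethylphenyl

The source may report more compounds than this note shows. Statements on the series, on what has been measured and on what is new or still open speak of the compounds shown alone.

Two compounds share a common core and differ only in the aryl group attached to the carbonyl carbon. Compound 1 `COc1ccc(/C=C/c2cc(OC)cc(OC)c2/C=C/C(=O)c2cccc(OC)c2)cc1` carries a 3-methoxyphenyl there, and in a functional assay on B16-F10 cells (Mus musculus) for antiproliferative activity, read by MTT assay, with a stated time of 48 h (a higher number here means a weaker inhibitor, a lower number a stronger inhibitor), compound 1 gives 4.3 ug/mL. Compound 2 `COc1ccc(/C=C/c2cc(OC)cc(OC)c2/C=C/C(=O)c2ccc(N)cc2)cc1` carries a 4-aminophenyl instead, and in this assay compound 2 gives 2.8 ug/mL. The step of a 1.5-fold lower number from compound 1 to compound 2 (0.19 log units; within the scatter) is small, so the two values cannot be told apart with confidence.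

Compound 3 `COc1ccc(/C=C/c2cc(OC)cc(OC)c2/C=C/C(=O)c2ccc(C)c(C)c2)cc1` is not yet measured. It differs from compound 2 in one place: 3,4-dimethylphenyl in place of 4-aminophenyl on a carbonyl carbon. For the measured compounds named here, the only measured step that touches this position is a 1.5-fold lower number from compound 1 to compound 2 (0.19 log units; within the scatter), and it stayed within the scatter. On that basis the expected step in this assay for compound 3 is also modest, with no clear direction; a slightly higher number is chosen because a 1.5-fold lower number from compound 1 to compound 2 (0.19 log units; within the scatter) went the other way when an aminophenyl arrived, and here it departs. The expected step is a 1.4-fold higher number from compound 2 to compound 3 (0.15 log units; within the scatter). Compound 3 is therefore estimated at 4 ug/mL, with a range from 2 ug/mL to 8 ug/mL.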

Compound 3, half-maximal inhibitory concentration: 1.4 ug/mL
The estimate for compound 3 lay 2.9-fold (0.46 log units) above the measured number, and the stated range ends above it.
By their numbers in this assay, from the lowest: compounds 3, 2 and 1 (each within the scatter of the next, the first and the last beyond it).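

In this assay, this position on the carbonyl carbon now gives its first step beyond the scatter: a 3.1-fold lower number from compound 1 to compound 3 (0.49 log units; beyond the scatter), a modest change that shows the choice of aryl group here can move the number measurably. Against the 4-aminophenyl group the picture is less firm, with a 2.0-fold lower number from compound 2 to compound 3 (0.30 log units; within the scatter), so a ring with 0 hydrogen-bond donors and 0 hydrogen-bond acceptors performs within the scatter of one that has one of each, and the donor and acceptor of 4-aminophenyl are not required for a number in this range. Nothing in the data gives a reason for either step.

What stays open is whether both methyl groups of 3,4-dimethylphenyl matter, since a ring carrying a single methyl is not among the compounds shown, so the step cannot be assigned to either one. It is also unknown how far this trend runs with a longer chain such as ethyl or propyl on the ring, or how a carboxylic acid would fare at this position.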